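Configuration at one stereocentre: compound 3 to compound 4

The source may hold more compounds than are shown below. What is called first, only, known or untested is meant among the compounds shown, and "the series" means these compounds.

Values in a functional assay on A549 cells (Homo sapiens) for inhibition, read by MTT assay, with a stated time of 72 h; a higher number here means a weaker inhibitor, a lower number a stronger inhibitor:
- Compound 1 `CC1=NN(c2ccccc2)C(=O)[C@]12C(=O)C=CC[C@@H]2c1ccc(C)cc1` gives 8600 nM
- Compound 2 `CC1=NN(c2ccc(C)cc2)C(=O)[C@]12C(=O)C=CC[C@H]2c1ccc(C)cc1` gives 7520 nM
- Compound 3 `CC1=NN(c2ccc(C)cc2)C(=O)[C@@]12C(=O)C=CC[C@@H]2c1ccc(C)cc1` gives 4320 nM

In this assay compound 3 stands within the scatter of both compound 1 and compound 2, so the three values give no ranking. The change to compound 4 `CC1=NN(c2ccc(C)cc2)C(=O)[C@]12C(=O)C=CC[C@@H]2c1ccc(C)cc1` is the two compounds have the same atoms and bonds and differ only in configuration as drawn: 1 of 2 stereo elements differ; a stereocentre at a saturated ring carbon is drawn R in compound 3 and S in compound 4 and nothing else. Going by the values given here, one measured step bears on this: a 1.7-fold lower number from compound 2 to compound 3 (0.24 log units; within the scatter) and it inverts both stereocentres, with the fact that compounds 2 and 3 differ only in the configuration as drawn as the only evidence. That step stays within the scatter, so no step beyond the scatter is expected here. The estimated step is a 1.4-fold higher number from compound 3 to compound 4 (0.14 log units; within the scatter) in this assay and it should be read as no real change. For compound 4 the estimated value is 6000 nM with an expected range of 2800 nM to 13000 nM in this read-out.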

Compound 4, half-maximal inhibitory concentration: 54300 nM
For compound 4 the middle estimate is 9.1-fold (0.96 log units) below the measured one; the whole stated range lies below it.
By their numbers in this assay, from the lowest: compounds 3, 2 and 1 (each within the scatter of the next); then compound 4.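

Configuration at a single stereocentre matters in this assay: there is a 13-fold higher number from compound 3 to compound 4 (1.10 log units; beyond the scatter) and a 7.2-fold higher number from compound 2 to compound 4 (0.86 log units; beyond the scatter), whereas the mirror images compound 2 and compound 3 stay within the scatter of each other. The change from compound 3 is assigned to configuration alone because of one fact: the fact that compounds 3 and 4 differ only in the configuration as drawn. With the configuration of compound 4, methyl in place of hydrogen on an aromatic carbon also counts, with a 6.3-fold higher number from compound 1 to compound 4 (0.80 log units; beyond the scatter).

Open, as far as these compounds go, is whether that methyl counts equally in the other configurations. Also open, from the compounds shown here alone, is how an amine or a carboxylic acid in its place would read in this assay.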